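This account rests on a few compounds, and the source may have more. Where it says the series, first, only, none or still open, it means among the compounds named here.

For the measured compounds named here, in a functional assay on A-431 cells (Homo sapiens) for antiproliferative activity, read by MTT assay, with a stated time of 72 h (a lower number here means a stronger inhibitor, a higher number a weaker inhibitor), compound 3 `C=CC(=O)Nc1c(OC)cc(OC)c2c(=O)n(-c3cccc(C(=O)N4CCCCC4)c3)ccc12` gives 6230 nM, the second highest of the three numbers measured so far; compound 1 `COc1cc(OC)c2c(=O)n(-c3cccc(C(=O)N4CCCCC4)c3)ccc2c1` gives 15300 nM, and compound 2 `COc1cc(O)c2c(=O)n(-c3cccc(C(=O)N4CCCCC4)c3)ccc2c1` gives 2250 nM. Compound 4 `C=CC(=O)Nc1c(OC)cc(O)c2c(=O)n(-c3cccc(C(=O)N4CCCCC4)c3)ccc12` has not yet been measured. It differs from compound 3 by hydrogen in place of methyl on an oxygen on an aromatic ring. The same change has been made once before, on a compound lacking the (vinylcarbonyl)amino group: a 6.8-fold lower number from compound 1 to compound 2 (0.83 log units; beyond the scatter), a step beyond the scatter. The other measured step, a 2.5-fold lower number from compound 1 to compound 3 (0.39 log units; beyond the scatter), is a different change and only shows that the (vinylcarbonyl)amino group itself shifts the number modestly. Because a 6.8-fold lower number from compound 1 to compound 2 (0.83 log units; beyond the scatter) points downward, a similar drop is expected: a 6.2-fold lower number from compound 3 to compound 4 (0.79 log units; beyond the scatter). The estimate for compound 4 is 1000 nM, within a range from 300 nM to 3500 nM.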

Compound 4, half-maximal inhibitory concentration: 5300 nM
The estimate for compound 4 lay 5.3-fold (0.72 log units) below the measured number; the whole stated range lies below it.
By their numbers in this assay, from the lowest: compound 2; then compounds 4 and 3 (each within the scatter of the next); then compound 1.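

On this core, methoxy to hydroxy no longer gives the drop seen without the (vinylcarbonyl)amino group, as the step is only a 1.2-fold lower number from compound 3 to compound 4 (0.07 log units; within the scatter). The size of this change therefore depends on what else the core carries: the same change on two cores in this assay, a 6.8-fold lower number (0.83 log units; beyond the scatter) from compound 1 to compound 2 and a 1.2-fold lower number (0.07 log units; within the scatter) from compound 3 to compound 4, 5.8-fold (0.76 log units) apart, beyond the scatter of two such steps

The reverse also holds, since on the hydroxy compound adding the (vinylcarbonyl)amino group gives a 2.4-fold higher number from compound 2 to compound 4 (0.37 log units; beyond the scatter), the opposite direction to its step on the methoxy compound: the same change on two cores in this assay, a 2.5-fold lower number (0.39 log units; beyond the scatter) from compound 1 to compound 3 and a 2.4-fold higher number (0.37 log units; beyond the scatter) from compound 2 to compound 4, 5.8-fold (0.76 log units) apart, beyond the scatter of two such steps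

On these data alone, whether an ethyl or a longer chain on this oxygen would follow the methoxy or the hydroxy compounds stays open. So does how an amine in place of the (vinylcarbonyl)amino group would behave.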